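A Third Methoxy on the Aryl Group of Compound 3

The compounds below may be only part of what the source reports. "The series", "measured", "known", "first", "only" and "open" are said of these compounds alone.

Compound 3 `COc1ccc(C2CC(c3cc(Cl)c(C)cc3O)=NN2c2ccc(S(N)(=O)=O)cc2)cc1OC` gives 36900 nM in a functional assay on HT-29 cells (Homo sapiens) for antiproliferative activity, with a stated time of 48 h; on this read-out lower numbers stand for higher toxicity in this test and higher numbers for lower toxicity in this test. Among the three measured compounds it holds the second highest number. Its nearest neighbour is compound 2 `Cc1cc(O)c(C2=NN(c3ccc(S(N)(=O)=O)cc3)C(/C=C/c3ccccc3)C2)cc1Cl`, which gives 38300 nM, the pair separated by a 1.0-fold lower number from compound 2 to compound 3 (0.02 log units; within the scatter). The furthest is compound 1 `Cc1cc(O)c(C2=NN(c3ccc(S(N)(=O)=O)cc3)C(c3ccccc3Cl)C2)cc1Cl`, which gives 6830 nM, the gap being a 5.4-fold higher number from compound 1 to compound 3 (0.73 log units; beyond the scatter).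

Compound 4 `COc1ccc(C2CC(c3cc(Cl)c(C)cc3O)=NN2c2ccc(S(N)(=O)=O)cc2)c(OC)c1OC` differs from compound 3 by methoxy in place of hydrogen on an aromatic carbon, the methoxy entering on an aromatic carbon of a six-membered aromatic ring of carbon only, ortho to a methoxy group. Among the compounds with values here, no measured step adds a single methoxy. The steps that exist exchange the whole group on the saturated ring carbon: a 5.6-fold higher number from compound 1 to compound 2 (0.75 log units; beyond the scatter) and a 5.4-fold higher number from compound 1 to compound 3 (0.73 log units; beyond the scatter), both modest, while a 1.0-fold lower number from compound 2 to compound 3 (0.02 log units; within the scatter) stays within the scatter. The change here is smaller than any of those exchanges, so compound 4 is expected to remain close to compound 3. The expected step is a 1.1-fold higher number from compound 3 to compound 4 (0.04 log units; within the scatter). Compound 4 is estimated at 40000 nM, within a range from 15000 nM to 100000 nM.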

Compound 4, concentration lethal to 50% of the cells: 9520 nM
Beside the measured number, compound 4's estimate is 4.2-fold (0.62 log units) above it, outside the stated range (below it).
By their numbers in this assay, from the lowest: compounds 1 and 4 (each within the scatter of the next); then compounds 3 and 2 (each within the scatter of the next).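

In this assay, adding one methoxy to the aryl group on the saturated ring carbon gives a clear step (a 3.9-fold lower number from compound 3 to compound 4 (0.59 log units; beyond the scatter)), whereas exchanging the whole group between the two earlier compounds gave none beyond the scatter (a 1.0-fold lower number from compound 2 to compound 3 (0.02 log units; within the scatter)). The 2,3,4-trimethoxyphenyl group also parts from 2-phenylethenyl (a 4.0-fold lower number from compound 2 to compound 4 (0.60 log units; beyond the scatter)) but not from 2-chlorophenyl (a 1.4-fold higher number from compound 1 to compound 4 (0.14 log units; within the scatter)), so among these four compounds a number in this lower range does not depend on a chlorine on that aryl group. Nothing reported here accounts for this shift.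

From the compounds shown here alone, whether a hydroxyl or a methyl on the same aromatic carbon would give a similar number remains open. So does whether the added methoxy would have the same effect without the two methoxy groups already present.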